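Removing the Chlorine from a Small Dihydroxybenzyl Ether

This account rests on a few compounds, and the source may have more. Where it says the series, first, only, none or still open, it means among the compounds named here.

Of the compounds shown here, three have been measured in a functional assay on Bel-7402 cells (Homo sapiens) for cytotoxicity, read by sulforhodamine B assay; on this read-out higher numbers stand for weaker inhibition and lower numbers for stronger inhibition. Compound 1 `Oc1ccc(O)c(COCc2cc(O)cc(Cl)c2O)c1` gives 62300 nM. Compound 2 `Oc1ccc(O)c(COCc2cc(O)ccc2O)c1` gives 57300 nM in this assay. The two differ by one change, (hydrogen in place of chloro on an aromatic carbon), and that step is a 1.1-fold lower number from compound 1 to compound 2 (0.04 log units; within the scatter). Compound 3 `COCc1cc(O)cc(Cl)c1O` is a smaller molecule; in this assay compound 3 gives 58100 nM, a number within the scatter of both compound 1 and compound 2. The difference between the core of compound 3 and the core of compound 1 is not broken down here.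

Compound 4 `COCc1cc(O)ccc1O` has not yet been measured. It differs from compound 3 by hydrogen in place of chloro on an aromatic carbon. Among the compounds with values here, this is the same kind of change as the one from compound 1 to compound 2; the surroundings differ in that the changed carbon is meta to a methoxymethyl group (3 heavy atoms) in compound 3 but meta to a large group in compound 1. Since the earlier step of a 1.1-fold lower number from compound 1 to compound 2 (0.04 log units; within the scatter) stayed within the scatter, a similar outcome is expected here: a 1.1-fold lower number from compound 3 to compound 4 (0.02 log units; within the scatter). Compound 4 is therefore estimated at 55000 nM in this assay, most likely between 30000 nM and 110000 nM. This expectation rests on a single earlier example of the change.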

Compound 4, half-maximal inhibitory concentration: > 100000 nM
Compound 4 ended at the assay's limit (the forecaster's own chance of this, stated with the estimate: 15%); at least 1.8-fold (0.25 log units) between middle value and limit.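

In this assay compound 4 gives > 100000 nM, which is a limit of the assay and not a number. Swapping the chloro group for hydrogen on this smaller molecule gives an at least 1.7-fold higher number from compound 3 to compound 4 (0.23 log units; that floor lies within the scatter), so this step is known only as a floor, and that floor itself lies within the usual scatter. Set beside the earlier step, this result shows neither that the change carries over unchanged from one core to the other nor that it behaves differently on the two: the same change on two cores in this assay, a 1.1-fold lower number (0.04 log units; within the scatter) from compound 1 to compound 2 and an at least 1.7-fold higher number (0.23 log units; that floor lies within the scatter) from compound 3 to compound 4; the limit leaves it open whether they differ.

The compounds shown leave open how far compound 4 truly lies from compound 3, and so whether the two steps would match if both were known as full numbers. They also leave open what a fluoro group, a methyl group or an amine would do on that same aromatic carbon, in place of chloro or hydrogen, on either core.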